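The source may report more compounds than this note shows. Statements on the series, on what has been measured and on what is new or still open speak of the compounds shown alone.

Measured in an ADME assay on NHDF cells (Homo sapiens) for cytotoxicity, read by MTT assay, with a stated time of 72 h; on this read-out higher numbers stand for weaker inhibition and lower numbers for stronger inhibition:
- compound 1 `COc1cccc(/C=C2\CCC/C(=C\c3ccc(Cl)cc3)C2=O)c1OC`: 18600 nM
- compound 2 `COc1cccc(/C=C2\CCC/C(=C\c3cc(Cl)cc(Cl)c3)C2=O)c1OC`: 21600 nM

Going by the values given here, compound 2 stands level with compound 1, as the only measured step is a 1.2-fold higher number from compound 1 to compound 2 (0.06 log units; within the scatter). Compound 3 `COc1cc(/C=C2\CCC/C(=C\c3cccc(OC)c3OC)C2=O)ccc1O` carries 4-hydroxy-3-methoxyphenyl in place of 3,5-dichlorophenyl on a double-bonded chain carbon bound to a double-bonded ring carbon. Among the compounds with values here, the one measured step at this place stayed within the scatter, but it only exchanged one chlorophenyl group for another, and no measured compound has a hydroxy group here. A step beyond the scatter in this assay is therefore not expected, though the uncertainty is wide. The expected change is a 1.3-fold lower number from compound 2 to compound 3 (0.10 log units; within the scatter). For compound 3 the estimate is 17000 nM, with an expected range of 6000 nM to 45000 nM.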

Compound 3, half-maximal inhibitory concentration: 14300 nM
Beside the measured number, compound 3's estimate is 1.2-fold (0.08 log units) above it; measured number inside the range.
By their numbers in this assay, from the lowest: compounds 3, 1 and 2 (each within the scatter of the next).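

In this assay a hydroxy-bearing group on a double-bonded chain carbon bound to a double-bonded ring carbon gives a 1.5-fold lower number from compound 2 to compound 3 (0.18 log units; within the scatter) and a 1.3-fold lower number from compound 1 to compound 3 (0.11 log units; within the scatter) against the two chlorophenyl groups. Going by these compounds alone, the place therefore tolerates more than an exchange of one chlorophenyl group for another: 4-hydroxy-3-methoxyphenyl, the first group here with a hydrogen-bond donor, stays within the scatter of both. No evidence on hand bears on this result.

Going by these compounds, whether an amine or a carboxylic acid at this place would give a step beyond the scatter stays open. On these data alone, the effect of any change elsewhere on the shared core also stays open.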